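Swapping Furan-2-yl for Thiophen-3-yl on a Shared Core

This account rests on a few compounds, and the source may have more. Where it says the series, first, only, none or still open, it means among the compounds named here.

Compound 1 `Nc1nc2c(c(-c3ccccc3)cn2[C@@H]2O[C@H](CO)[C@@H](O)[C@H]2O)c(=O)[nH]1` — > 20000 nM
Compound 2 `O=c1[nH]cnc2c1c(-c1ccsc1)cn2[C@@H]1O[C@H](CO)[C@@H](O)[C@H]1O` — > 15000 nM
Compound 3 `Nc1nc2c(c(-c3ccco3)cn2[C@@H]2O[C@H](CO)[C@@H](O)[C@H]2O)c(=O)[nH]1` — > 20000 nM

In a functional assay on HepG2 cells (Homo sapiens) for antiproliferative activity, read by XTT assay, with a stated time of 72 h (a higher number here means a weaker inhibitor, a lower number a stronger inhibitor), compound 3 gives only a limit, > 20000 nM, and not a number. Compound 1 likewise sits at a limit, > 20000 nM. Compound 2 too reaches only a limit, > 15000 nM. Thus none of the three measured compounds has a readable value in this assay, and compound 3 stands with the two others at the edge of what the assay reports.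

Among the compounds with values here, the one step between measured compounds that differ in a single place is a step that the two limits leave unreadable from compound 1 to compound 3; with both ends at limits its size cannot be read. Compound 4 `Nc1nc2c(c(-c3ccsc3)cn2[C@@H]2O[C@H](CO)[C@@H](O)[C@H]2O)c(=O)[nH]1` differs from compound 3 by thiophen-3-yl in place of furan-2-yl on an aromatic carbon. The only step that bears on this change is the unreadable one from compound 1 to compound 3, so it gives no direction; what is known is that the limit of > 20000 nM in this assay, at which 2 of the 3 values shown sit, and (the limit of > 15000 nM in this assay, at which 1 of the 3 values shown sits), and every compound shown with this core stays at a limit.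

Compound 4 is therefore expected to return a limit as well, with the step of a number no higher from compound 3 to compound 4 (the limit leaves the size open) not expected to rise above the scatter. The estimate for compound 4 is 20000 nM, in the range 10000 nM to 40000 nM.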

Compound 4, half-maximal inhibitory concentration: > 20000 nM
Compound 4: only a limit was reported (the forecaster's own chance of this, stated with the estimate: 85%); the middle value sits exactly at the limit.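

In this assay compound 4 gives > 20000 nM, a limit and not a number. With limits at both ends, the steps to compound 4 from compound 1, compound 2 and compound 3 cannot be read. The compounds shown leave open whether phenyl, furan-2-yl and thiophen-3-yl differ at all on the shared core in this assay, and what amino in place of hydrogen does there.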